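The source may report more compounds than this note shows. Statements on the series, on what has been measured and on what is new or still open speak of the compounds shown alone.

Working notes on the series. The shared core carries two trifluoromethyl groups; compound 1 `C=CS(=O)(=O)c1cc(C(F)(F)F)cc(C(F)(F)F)c1` bears a vinylsulfonyl, compound 2 `O=C1C=CC(=O)N1c1cc(C(F)(F)F)cc(C(F)(F)F)c1` a maleimide, compound 3 `C=Cc1cc(C(F)(F)F)cc(C(F)(F)F)c1` a vinyl. In an ADME assay for pharmacokinetics, read by LC-MS, in phosphate buffer, with a stated time of 72 h, at pH 7.4, tested at 250 uM (a higher number here means that the compound lasts longer, a lower number that the compound disappears faster), compound 1 gives only a limit, < 0.017 h. In this assay compound 2 likewise gives only a limit, < 0.017 h. In this assay compound 3 gives only a limit, > 50 h, which is the upper end of what is shown. Compound 4 `N#Cc1cc(C(F)(F)F)cc(C(F)(F)F)c1` differs from compound 3 by cyano in place of vinyl on an aromatic carbon. Going by the values given here, the steps that bear on the vinyl are an at least 2900-fold higher number from compound 1 to compound 3 (3.46 log units; beyond the scatter) and an at least 2900-fold higher number from compound 2 to compound 3 (3.46 log units; beyond the scatter); both move toward the vinyl and are large. Among the compounds with values here, exchanging the vinyl for a cyano has no measured counterpart here, so no shift beyond the scatter is expected in this assay, and a number no higher from compound 3 to compound 4 (the limit leaves the size open) is estimated. Compound 4 is expected at 50 h, within 20 h to 200 h.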

Compound 4, half-life: > 50 h
Compound 4: only a limit was reported; the forecaster's own chance of this, stated with the estimate: 75%; the middle value sits exactly at the limit.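

With cyano on this aromatic carbon, this assay gives an at least 2900-fold higher number from compound 1 to compound 4 (3.46 log units; beyond the scatter) and an at least 2900-fold higher number from compound 2 to compound 4 (3.46 log units; beyond the scatter). Compound 4 thus shows that a second group, besides the vinyl of compound 3, ends at the upper limit of the read-out: the limit of > 50 h in this assay, at which 2 of the 4 values shown sit.

From the compounds shown here alone, both of these values are limits, so the step between compound 3 and compound 4 cannot be read, and any difference between vinyl and cyano stays open. Also open, going by these compounds, is how an amine or a carboxylic acid on this aromatic carbon would behave in this assay.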